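This account rests on a few compounds, and the source may have more. Where it says the series, first, only, none or still open, it means among the compounds named here.

Working notes on the series.

Three compounds have numbers in an ADME assay on cells (Hepatocyte, Rattus norvegicus) for metabolic stability; a higher number here means faster removal of the compound, a lower number slower removal. Compound 1 `Cc1cc(N(C)C)ccc1-c1nnc(N(C)Cc2ccc3nccn3c2)o1` gives 44 uL/min in this assay. Compound 2 `CNC(=O)c1sc(N2CC3CC2(CNC(=O)c2c[nH]c4ncc(C(F)(F)F)cc24)C3)nc1C(F)(F)F` gives 78 uL/min in this assay, the highest of the two numbers shown; the number for compound 1 is lower by an amount that sits within the scatter of repeated runs, so no order between compound 1 and compound 2 can be read from these two values. Compound 3 `C[C@@H]1CN(c2cnc(Nc3cc(F)c(OCC4CC4)c(F)c3)nc2NC2CCOCC2)CCN1` gives only a limit of the assay, < 2.4 uL/min, not a number; this is the floor at which one of the three values sits (the limit of < 2.4 uL/min in this assay, at which 1 of the 3 values shown sits).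

Among the compounds with values here, no pair of measured compounds differs in a single place, so there is no measured step to lean on.

Compound 4 `CNC(=O)c1sc(N2CC3CC2(CNC(=O)c2c[nH]c4ncc(C)cc24)C3)nc1C(F)(F)F` is the one not yet measured. It differs from compound 2 as follows: methyl in place of trifluoromethyl on an aromatic carbon. The change is small in count, trifluoromethyl out, methyl in, on the same aromatic carbon of the fused six-membered ring bearing one nitrogen.

With no measured step of this kind in the set, the expectation rests on the number for compound 2 alone, 78 uL/min. A moderate rise in this assay is expected for the step of a 1.4-fold higher number from compound 2 to compound 4 (0.15 log units; within the scatter), though a result within the scatter cannot be excluded. Compound 4 is therefore expected to give about 110 uL/min in this assay, with a range from 50 uL/min to 250 uL/min.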

Compound 4, intrinsic clearance in a liver preparation (reported as CLH), per the amount of preparation that the assay uses: 92 uL/min
For compound 4 the middle estimate is 1.2-fold (0.08 log units) above the measured one; low and high end bracket the measured number.
By their numbers in this assay, from the lowest: compounds 1, 2 and 4 (each within the scatter of the next, the first and the last beyond it). At a limit, below all of these: compound 3.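

Within the data shown here, this is the first step that can be read at a single place. In this assay, methyl in place of trifluoromethyl, on an aromatic carbon of the six-membered aromatic ring with 1 nitrogen, gives a 1.2-fold higher number from compound 2 to compound 4 (0.07 log units; within the scatter), so the pair cannot be told apart and no order can be read between them. Among these compounds, at this position, then, a group of 4 heavy atoms including 3 fluorine can give way to a single carbon with no separation of the two numbers, which the earlier compounds, none of them differing in one place, could not show. No measured property in the data on hand bears on this step.

This rests on a single pair, and it leaves open whether a more different group at the same aromatic carbon, such as an amine, a carboxylic acid or a longer chain, would move the number beyond the scatter. It also leaves open whether methyl in place of trifluoromethyl elsewhere on the shared core, including the trifluoromethyl that compounds 2 and 4 both retain on their other ring, would read the same way in this assay.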